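The source may hold more compounds than are shown below. What is called first, only, known or untested is meant among the compounds shown, and "the series" means these compounds.

Compound 2 `O=C(COCc1ccccn1)N1CCN(c2ccc(Cl)cc2Cl)CC1` is a positive allosteric modulator of the glutamate receptor studied here. In a functional assay on HEK293 cells for positive allosteric modulation of metabotropic glutamate receptor 5 (Homo sapiens), read by FLIPR and calcium flux (on this read-out higher numbers stand for an effect only at larger amounts of compound and lower numbers for an effect already at smaller amounts), compound 2 gives 310 nM, the lowest of the two numbers recorded, and compound 1 `O=C(COCc1ccncc1)N1CCN(c2ccc(Cl)cc2F)CC1` sits close by with 600 nM, a gap that falls within the usual scatter. Compound 3 `CN(CC(=O)N1CCN(c2ccc(Cl)cc2Cl)CC1)Cc1ccncc1` yields only a limit, > 25000 nM, a case of the limit of > 25000 nM in this assay, at which 1 of the 3 values shown sits. The unmeasured compound 4 `O=C(CSCc1ccccc1)N1CCN(c2ccc(Cl)cc2Cl)CC1` differs from compound 2 in one place: benzylsulfanyl in place of (pyridin-2-yl)methoxy on a saturated chain carbon bound to a carbonyl carbon. Among the compounds with values here, no pair of measured compounds shows such a change, so the direction is open; a moderate loss of potency is expected, meaning a step of a 2.3-fold higher number from compound 2 to compound 4 (0.35 log units; beyond the scatter). Compound 4 is accordingly estimated at 700 nM, with a plausible range from 150 nM to 3500 nM.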

Compound 4, half-maximal effective concentration: 7100 nM
Compound 4: middle estimate off by 10-fold (1.01 log units), on the low side; measured number outside the range, above it.
By their numbers in this assay, from the lowest: compounds 2 and 1 (each within the scatter of the next); then compound 4. At a limit, above all of these: compound 3.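

In this assay, the saturated chain carbon bound to a carbonyl carbon proves sensitive to this change, with a large step of a 23-fold higher number from compound 2 to compound 4 (1.36 log units; beyond the scatter). Benzylsulfanyl has as many heavy atoms as (pyridin-2-yl)methoxy, so matching that count does not keep the value. Nothing shown here explains the loss. The change replaces the ring nitrogen with carbon and the chain oxygen with sulfur at once, so the two swaps cannot be separated. Benzyloxy, which pairs the chain oxygen with the carbon-only ring, would help to show which swap carries the step.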